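One Ring Swapped, and the Unbound Fraction in Question

The source may report more compounds than this note shows. Statements on the series, on what has been measured and on what is new or still open speak of the compounds shown alone.

In an ADME assay on the whole organism (plasma, Rattus norvegicus) for protein binding, using cassette dosing, at a dose of 1 mg/kg (a higher number here means a larger unbound share of the compound, a lower number a smaller unbound share), compound 1 `Cc1ccc(Cn2c(=O)n(CC(C)(C)C(=O)O)c(=O)[nH]/c2=N\c2ccc(OC(C)C)c(Cl)c2)cc1` gives 0.01 and compound 2 `C[C@@H](Cn1c(=O)[nH]/c(=N\c2ccc(Oc3nccs3)cc2)n(Cc2ccc(Cl)cc2)c1=O)C(=O)O` gives 0.006 as its result. These two numbers lie within the usual scatter of repeated measurements, so compound 2 stands level with compound 1 on the data so far. Compound 3 `C[C@@H](Cn1c(=O)[nH]/c(=N\c2ccc(Oc3ccc(F)cn3)cc2)n(Cc2ccc(Cl)cc2)c1=O)C(=O)O` is the same as compound 2 except for one group: it carries 5-fluoropyridin-2-yl in place of 1,3-thiazol-2-yl on an oxygen on an aromatic ring in the structure. For the measured compounds named here, no measured pair shows a change made in one place alone, so the expectation rests only on compound 2 with its 0.006 in this assay as the starting point. The expected step of a 1.2-fold lower number from compound 2 to compound 3 (0.08 log units; within the scatter) stays within the scatter, with at most a slight drop. For compound 3 the estimated unbound fraction is 0.005 with an expected range from 0.002 to 0.012 as its limits of likely outcome.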

Compound 3, unbound fraction: 0.011
The estimate for compound 3 lay 2.2-fold (0.34 log units) below the measured number; measured number inside the range.
By their numbers in this assay, from the lowest: compounds 2, 1 and 3 (each within the scatter of the next).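

In this assay, putting 5-fluoropyridin-2-yl in place of 1,3-thiazol-2-yl on an oxygen on an aromatic ring gives a 1.8-fold higher number from compound 2 to compound 3 (0.26 log units; within the scatter). For the compounds shown here, this is the first pair that differs in one place alone, so it is the first direct reading of this position. It shows that a five-membered aromatic ring with 2 hetero atoms and a six-membered aromatic ring with 1 hetero atom and a fluorine cannot be told apart here by unbound fraction, and no supporting data bear on this result.

This single pair leaves the wider tolerance of the position open. On these data alone, whether a nitrile in place of the fluorine, or an amine on the pyridine ring, would shift the unbound fraction beyond the scatter remains unknown.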